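Swapping the Amide Aryl Group: Expected Cytotoxicity of Compound 3

The compounds below may be only part of what the source reports. "The series", "measured", "known", "first", "only" and "open" are said of these compounds alone.

Compound 2 `Cc1cccc(NC(=O)c2cccc(/C=C3\CC(=O)N(c4ccccc4)C3=O)c2)c1` was tested in an ADME assay on SW480 cells (Homo sapiens) for cytotoxicity, read by MTT assay, with a stated time of 72 h; on this read-out lower numbers stand for stronger inhibition and higher numbers for weaker inhibition. In this assay compound 2 gives > 100000 nM, which is a limit of the assay rather than a measured number. Compound 1 `CCc1ccc(NC(=O)c2cccc(/C=C3\CC(=O)N(c4ccccc4)C3=O)c2)cc1` shares the same core and differs only on the amide-type nitrogen. In this assay compound 1 gives > 100000 nM, again a limit. Among the measured compounds shown here, the only measured step, a step that the two limits leave unreadable from compound 1 to compound 2, cannot be read in size because of the limit of > 100000 nM in this assay, at which 2 of the 2 values shown sit. Compound 3 `O=C(Nc1ccc(OC(F)F)cc1)c1cccc(/C=C2\CC(=O)N(c3ccccc3)C2=O)c1` carries the next change: 4-(difluoromethoxy)phenyl in place of 3-methylphenyl on an amide-type nitrogen. For the measured compounds named here, no measured step bears on this change with a readable size, so the data give no direction for it. Compound 3 is therefore expected to show a step of about a number no higher from compound 2 to compound 3 (the limit leaves the size open), which is no change beyond the scatter. The estimate for compound 3 is 100000 nM, with a range from 30000 nM to 300000 nM, and it is expected most likely to come back as a limit once more.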

Compound 3, half-maximal inhibitory concentration: > 100000 nM
Compound 3: a limit, no number; the forecaster's own chance of this, stated with the estimate: 75%; the middle value lies on the limit itself.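

Among the compounds shown here, compound 1, compound 2 and compound 3 all return only a limit in this assay, so no step among them can be read in size, because: the limit of > 100000 nM in this assay, at which 3 of the 3 values shown sit.

The compounds shown leave open whether any aryl group on the amide nitrogen brings a readable value in this assay at all.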